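The source may hold more compounds than are shown below. What is called first, only, known or untested is meant among the compounds shown, and "the series" means these compounds.

Compound 1 `CCCn1c(=O)[nH]c2nc(-c3ccc(S(=O)(=O)N4CCN(c5ccccc5C)CC4)cc3)[nH]c2c1=O` carries a 2-methylphenyl on the ring amine. In an assay on CHO cells for displacement of a labelled ligand from adenosine receptor A3 (Homo sapiens), read by scintillation counting, with a stated time of 45 min, in the presence of a further agent that is not named here (on this read-out higher numbers stand for weaker inhibition and lower numbers for stronger inhibition), compound 1 gives only a limit, > 1000 nM. Compound 3 `CCCn1c(=O)[nH]c2nc(-c3ccc(S(=O)(=O)N4CCN(Cc5ccc(Br)c(F)c5)CC4)cc3)[nH]c2c1=O` likewise reaches only a limit in this assay, > 1000 nM. Compound 2 `CCCn1c(=O)[nH]c2nc(-c3ccc(S(=O)(=O)N4CCN(c5cccc(Cl)c5)CC4)cc3)[nH]c2c1=O` gives 53.5 nM in this assay; the step of an at least 18-fold lower number from compound 1 to compound 2 (1.27 log units; beyond the scatter) is large, as is an at least 18-fold higher number from compound 2 to compound 3 (1.27 log units; beyond the scatter), with two of the three values sitting at the limit of > 1000 nM in this assay, at which 2 of the 3 values shown sit. Compound 4 `CCCn1c(=O)[nH]c2nc(-c3ccc(S(=O)(=O)N4CCN(c5ccccc5)CC4)cc3)[nH]c2c1=O` differs from compound 1 by hydrogen in place of methyl on an aromatic carbon. Going by the values given here, only the step to compound 2 alters the same aryl group, and it runs toward stronger inhibition. A smaller step in that direction is expected in this assay, an at least 2.5-fold lower number from compound 1 to compound 4 (0.39 log units; beyond the scatter). Compound 4 is therefore estimated at 400 nM, within 100 nM to 3000 nM, a further limit remaining possible.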

Compound 4, inhibition constant: > 1000 nM
Compound 4: only a limit was reported (the forecaster's own chance of this, stated with the estimate: 35%); middle value at least 2.5-fold (0.39 log units) away from the limit.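

In this assay compound 4 gives only a limit, > 1000 nM, so a plain phenyl on the ring amine does not yield a readable value. Hydrogen in place of chloro gives an at least 18-fold higher number from compound 2 to compound 4 (1.27 log units; beyond the scatter), which ties the readable value of compound 2 to its chloro group. The steps to compound 4 from compound 1 and compound 3 cannot be read, since both ends of each are limits, and the effect of removing the methyl stays unresolved: the limit of > 1000 nM in this assay, at which 3 of the 4 values shown sit.

Still open, as far as these compounds go, is whether a fluoro, a methoxy or a nitrile in place of that chloro also gives a readable value.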